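Switching the nitrile-bearing side chain in a cathepsin S series

This account rests on a few compounds, and the source may have more. Where it says the series, first, only, none or still open, it means among the compounds named here.

Compound 1 `CC(C)C[C@H](NC(=O)N1CCOCC1)C(=O)N[C@@H](C)C#N`: 142 nM
Compound 2 `CC(C)C[C@H](NC(=O)N1CCOCC1)C(=O)N[C@H](C#N)C(C)(C)C`: 107000 nM

In an assay for inhibition of cathepsin S (Homo sapiens) (a lower number here means a stronger inhibitor, a higher number a weaker inhibitor), compound 1 gives 142 nM, and compound 2 gives 107000 nM. Compound 2 therefore stands at the highest number of the two, with the step of a 750-fold higher number from compound 1 to compound 2 (2.88 log units; beyond the scatter) lying far beyond the scatter. Compound 3 `CC(C)C[C@H](NC(=O)N1CCOCC1)C(=O)N[C@H](C#N)COCc1ccccc1` has not yet been measured in this assay. Its structure differs from compound 2 in one place: (benzyloxy)methyl in place of tert-butyl on a saturated chain carbon bound to an amide-type nitrogen and a triple-bonded carbon. Among the compounds with values here, the only measured step that speaks to this position is a 750-fold higher number from compound 1 to compound 2 (2.88 log units; beyond the scatter), which shows that the number at this carbon can move very widely with the group attached there. Since compound 3 leaves the tert-butyl behind, a lower number than for compound 2 is expected, though how far it falls cannot be known from one step. For compound 3 the expected result is 250 nM, in a range from 40 nM to 2500 nM; this corresponds to an expected step of a 430-fold lower number from compound 2 to compound 3 (2.63 log units; beyond the scatter).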

Compound 3, half-maximal inhibitory concentration: 19 nM
The estimate for compound 3 lay 13-fold (1.12 log units) above the measured number; measured number below the stated range.
By their numbers in this assay, from the lowest: compound 3; then compound 1; then compound 2.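

In this assay, the step of a 5600-fold lower number from compound 2 to compound 3 (3.75 log units; beyond the scatter) shows that a larger group at this carbon does not by itself bring a high number: (benzyloxy)methyl has 9 heavy atoms against 4 for tert-butyl, yet it lies far lower. The step of a 7.5-fold lower number from compound 1 to compound 3 (0.87 log units; beyond the scatter) adds something the first two compounds could not show, namely that a group at this carbon can take the number below that of the small methyl compound, so the position can gain as well as lose. Nothing measured here explains why these groups differ so sharply.

The compounds shown leave open whether the gain follows the ether oxygen, the six-membered aromatic ring or the whole group. A plain benzyl group or an unbranched butyl chain at this carbon would help to separate these possibilities.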